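The compounds below may be only part of what the source reports. "The series", "measured", "known", "first", "only" and "open" are said of these compounds alone.

Working notes on a small set of inhibitors tested in an assay on isolated protein for inhibition of retinal dehydrogenase 2 (Homo sapiens); on this read-out higher numbers stand for weaker inhibition and lower numbers for stronger inhibition. Compound 1 `CC(Sc1nc2c(cnn2C)c(=O)n1-c1ccc(CCO)cc1)c1ccccc1` gives 216 nM and compound 3 `Cn1ncc2c(=O)n(-c3ccccc3)c(/C=C/c3cccc(F)c3)nc21` gives 440 nM. Compound 2 `Cn1ncc2c(=O)n(-c3ccccc3)c(SC(C)(C)c3ccccc3)nc21` gives 2200 nM, the highest of the three numbers, with compound 3 nearest and compound 1 furthest, both gaps beyond the scatter. Compound 4 `CC(Sc1nc2c(cnn2C)c(=O)n1-c1ccccc1)c1cncnc1` differs from compound 2 in one place: 1-(pyrimidin-5-yl)ethyl in place of 1-methyl-1-phenylethyl on a sulfur. Within the data shown here, no measured pair covers this change, so the expectation rests on the three values alone. A step down, beyond the scatter, is expected, since compound 1 gives 216 nM with its own sulfur-linked group; the expected step is a 4.4-fold lower number from compound 2 to compound 4 (0.64 log units; beyond the scatter). For compound 4 the estimate in this assay is 500 nM, with a range from 150 nM to 1800 nM.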

Compound 4, half-maximal inhibitory concentration: 380 nM
Beside the measured number, compound 4's estimate is 1.3-fold (0.12 log units) above it; the measured number falls inside the stated range.
By their numbers in this assay, from the lowest: compounds 1, 4 and 3 (each within the scatter of the next, the first and the last beyond it); then compound 2.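

In this assay, 1-(pyrimidin-5-yl)ethyl in place of 1-methyl-1-phenylethyl on a sulfur gives a 5.8-fold lower number from compound 2 to compound 4 (0.76 log units; beyond the scatter) and shows that this position responds to the group it carries. A six-membered aromatic ring with 2 hetero atoms is accepted there, but this one step changes the ring and the carbon count together and cannot separate them. No measured property bears on this step.

Open, from the compounds shown here alone, is whether 1-phenylethyl on the same sulfur, with the rest of compound 4 unchanged, would read closer to compound 4 or compound 2. Also open, going by these compounds, is how a pyridine ring in place of the pyrimidine, or an amine on that ring, would read.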